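The compounds below may be only part of what the source reports. "The series", "measured", "known", "first", "only" and "open" are said of these compounds alone.

Two cyanoguanidine compounds on a pyridazinone core have been measured so far in a functional assay on the whole organism with Rattus norvegicus as the target, at a dose of 100 mg/kg; a higher number here means more inhibition at the dose given (going by the name of the read-out), a lower number less inhibition. Compound 1, with the structure `CC/N=C(/NC#N)NCCCn1nc(-c2ccccc2)cc(C)c1=O`, gives 23.5% in this assay. Compound 2, with the structure `C/N=C(/NC#N)NCCCCn1nc(N(C)C)ccc1=O`, gives 26.3% in this assay. The two numbers sit within the usual scatter of each other, so compound 2 does not stand apart from compound 1 on the evidence at hand.

Compound 3, with the structure `C/N=C(/NC#N)NCCCCn1nc(N2CCCC2)ccc1=O`, has not yet been measured. Relative to compound 2 it carries the change (pyrrolidin-1-yl in place of dimethylamino on an aromatic carbon). For the measured compounds named here, no measured pair shows a comparable step, so the direction is uncertain. The step from compound 2 to compound 3 is expected to be small, a number 3.7 percentage points higher from compound 2 to compound 3 (within the scatter), and not clearly beyond the scatter. Compound 3 is therefore expected to give about 30%, somewhere between 10% and 52% in this assay.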

Compound 3, a percentage reported as inhibition, in the whole organism at one dose (the size of the read-out at that dose, not a potency): -1%
Beside the measured number, compound 3's estimate is 31 percentage points above it; the measured number lies below the stated range.
By their numbers in this assay, from the lowest: compound 3; then compounds 1 and 2 (each within the scatter of the next).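

Swapping one amine for another at this aromatic carbon, next to the ring nitrogen, is not a neutral change in this assay: the step with pyrrolidin-1-yl in place of dimethylamino is a number 27.3 percentage points lower from compound 2 to compound 3 (beyond the scatter) and is the first difference in the series that stands clear of the scatter. The position therefore matters to this read-out, and at this dose compound 3 gives -1% in a setting where the open dimethylamino group retains its modest inhibition. Nothing in the available data accounts for the drop.

With only this one pair, it remains open whether the loss goes with the ring itself or with the larger group, since neither diethylamino, an open-chain amine with more carbon, nor piperidin-1-yl or morpholin-4-yl appears among the compounds shown. A plain hydrogen or a methoxy group at this carbon is equally absent, so the contribution of the dimethylamino group itself also stays undefined.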